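From fluoro to bromo on compound 1

The compounds below may be only part of what the source reports. "The series", "measured", "known", "first", "only" and "open" are said of these compounds alone.

Measured so far in a functional assay on SGC-7901 cells (Homo sapiens) for inhibition, read by MTT assay, with a stated time of 72 h; a lower number here means a stronger inhibitor, a higher number a weaker inhibitor
Compound 1 `O=C1Nc2ccccc2/C1=C\C(=O)c1ccccc1F` gives 17400 nM here
Compound 2 `CC(=O)Nc1cccc(C(=O)/C=C2/C(=O)Nc3ccccc32)c1` gives 14100 nM here
Compound 3 `Nc1cccc(C(=O)/C=C2/C(=O)Nc3ccccc32)c1` gives 14400 nM here

Compound 1 lies within the scatter of both compound 2 and compound 3, so the three values show no order. Compound 4 `O=C1Nc2ccccc2/C1=C\C(=O)c1ccccc1Br` rests on one change from compound 1 (bromo in place of fluoro on an aromatic carbon). Among the compounds with values here, no measured step makes this exchange. Within the data shown here, the only measured step of a 1.0-fold higher number from compound 2 to compound 3 (0.01 log units; within the scatter) puts hydrogen in place of acetyl on a nitrogen on an aromatic ring and stays within the scatter, so it gives no sign of a large shift. In this assay no change beyond the scatter is expected in either direction. The expected step is a 1.2-fold lower number from compound 1 to compound 4 (0.09 log units; within the scatter) and no more than that. For compound 4 the estimate is 14000 nM with an expected range from 6500 nM to 30000 nM in this measurement.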

Compound 4, half-maximal inhibitory concentration: 13100 nM
Estimate against measurement, compound 4: 1.1-fold (0.03 log units) above; the measured number falls inside the stated range.
By their numbers in this assay, from the lowest: compounds 4, 2, 3 and 1 (each within the scatter of the next).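

In this assay, bromo in place of fluoro on an aromatic carbon, ortho to a large group, gives a 1.3-fold lower number from compound 1 to compound 4 (0.12 log units; within the scatter) and stays within the scatter. Within the data shown here, this is the first measured exchange at this position, and it shows that one halogen can replace the other here with no clear shift in the number. No measurement given here bears on why this exchange leaves the number within the scatter. Still open, on these data alone, is whether a group other than a halogen at this position, such as a carboxylic acid or a methoxy group, would move the number beyond the scatter.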